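A Side-Group Swap on a Shared Core: Compound 3 to 4

The source may hold more compounds than are shown below. What is called first, only, known or untested is meant among the compounds shown, and "the series" means these compounds.

Of the compounds shown here, three have so far been tested in an assay on isolated protein for inhibition of tyrosine-protein kinase ZAP-70 (Homo sapiens), read by HTRF, tested at 10 uM; on this read-out lower numbers stand for less inhibition and higher numbers for more inhibition at the one concentration tested (going by the name of the read-out). Compound 1 `COC[C@@H]1CCCN1C(=O)C1CCCN1c1cc(Nc2cccc(Br)c2)ncn1` gives 0%, compound 2 `COC[C@@H]1CCCN1C(=O)[C@@H]1CCCN1c1cc(Nc2cccc(OC)c2)nc(N)n1` gives 0%, and compound 3 `Clc1ccc2sc(CN3CCN(c4ncnc5c4CN(Cc4ccccc4)CC5)CC3)cc2c1` gives 5%. Compound 3 holds the highest of the three numbers, but its distance to compound 1 and to compound 2 lies within the usual scatter of this kind of measurement, so none of the three can be said to inhibit more than the others; all sit close to no inhibition at the single concentration tested.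

Compound 4 `O=C(CN1CCN(c2ncnc3c2CN(Cc2ccccc2)CC3)CC1)Nc1cc(F)ccc1F` keeps the core of compound 3 and differs in one place: (2,5-difluorophenyl)carbamoyl in place of 5-chloro-1-benzothiophen-2-yl on a saturated chain carbon bound to an amine nitrogen in a ring. Among the measured compounds shown here, no step between two measured compounds is available to show what such a change does in this assay, so the expectation rests only on where compound 3 stands. For the measured compounds named here, because compound 3 gives 5%, and every number so far lies near the bottom of the scale, the step of a number 2 percentage points lower from compound 3 to compound 4 (within the scatter) is expected to stay within the scatter, in no clear direction. Compound 4 is therefore estimated at 3%, with a likely range from -5% to 12%.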

Compound 4, a percentage reported as inhibition, at one concentration (the size of the read-out at that concentration, not a potency): 5%
The estimate for compound 4 lay 2 percentage points below the measured number; low and high end bracket the measured number.
By their numbers in this assay, from the lowest: compounds 1, 2, 3 and 4 (each within the scatter of the next).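

In this assay, putting (2,5-difluorophenyl)carbamoyl in place of 5-chloro-1-benzothiophen-2-yl on a saturated chain carbon bound to an amine nitrogen in a ring gives no change at the digits printed from compound 3 to compound 4 (within the scatter). Among the compounds shown here, this is the first direct comparison at this position, and the exchange is a large one: the sulfur and chlorine leave, a five-membered aromatic ring is lost, and a hydrogen-bond donor enters where the leaving group has none. Even so, this change leaves the number within the scatter and close to no inhibition, and nothing measured here offers an explanation for that.

Both compounds sit so near the bottom of the scale that this single step cannot show whether the position matters for inhibition of the protein or whether the shared core simply gives little inhibition at the one concentration tested. From the compounds shown here alone, it also remains open whether a different group on that saturated chain carbon, such as a carboxylic acid, a primary amine or a longer alkyl chain, would lift the number beyond the scatter.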